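The compounds below may be only part of what the source reports. "The series", "measured", "known", "first", "only" and "open" are said of these compounds alone.

Going by the values given here, compound 3 `CCCCCCCCCCCCCCC(CNCC(=O)OCC)NC(=O)OC(C)(C)C` gives the highest number of the three measured so far in a functional assay on Jurkat cells (Homo sapiens) for inhibition (a higher number here means a weaker inhibitor, a lower number a stronger inhibitor), namely 28000 nM. Compound 2 `CCCCCCCCCCCCCCC(CN)NC(=O)OC(C)(C)C` gives 6000 nM, and compound 1 `CCCCCCCCCCCCCCC(COCc1ccccc1)NCC(=O)O` gives 3000 nM. Compound 4 `CCCCCCCCCCCCCCC(CN(CC)CC)NC(=O)OC(C)(C)C` differs from compound 3 by diethylamino in place of ((ethoxycarbonyl)methyl)amino on a saturated chain carbon, two bonds along the chain from an amide-type nitrogen. Among the compounds with values here, the one step that bears on this is the measured one, a 4.7-fold higher number from compound 2 to compound 3 (0.67 log units; beyond the scatter), in which the same nitrogen gained the (ethoxycarbonyl)methyl group that compound 4 now loses again, though compound 4 carries two ethyl groups instead of a hydrogen. Removing the ester is therefore expected to bring the number back toward that of compound 2, so a moderate downward step is expected, a 2.8-fold lower number from compound 3 to compound 4 (0.45 log units; beyond the scatter). Compound 4 is estimated at 10000 nM, with a range from 3000 nM to 35000 nM.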

Compound 4, half-maximal inhibitory concentration: 21000 nM
For compound 4 the middle estimate is 2.1-fold (0.32 log units) below the measured one; low and high end bracket the measured number.
By their numbers in this assay, from the lowest: compounds 1 and 2 (each within the scatter of the next); then compounds 4 and 3 (each within the scatter of the next).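

In this assay, replacing ((ethoxycarbonyl)methyl)amino with diethylamino gives a 1.3-fold lower number from compound 3 to compound 4 (0.12 log units; within the scatter), so the ester group is not needed for the difference from compound 2. The step to the free amino group remains, at a 3.5-fold higher number from compound 2 to compound 4 (0.54 log units; beyond the scatter), and so both substituted nitrogens in compound 3 and compound 4 stand apart from compound 2 by similar margins. Nothing available bears on why this is so. Open, going by these compounds, is whether a single ethyl on that nitrogen, or a carboxylic acid in place of the ethyl ester, would read the same.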